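The source may hold more compounds than are shown below. What is called first, only, known or untested is meant among the compounds shown, and "the series" means these compounds.

Compound 1, `Cn1c(=O)c(=O)n(C2CCCC2)c2nc(N/N=C/c3ccc(O)cc3)ncc21` — in a functional assay on PC-3 cells (Homo sapiens) for antiproliferative activity, read by MTT assay (a higher number here means a weaker inhibitor, a lower number a stronger inhibitor), compound 1 gives > 100000 nM, a limit of the assay.
Compound 2, `Cn1c(=O)c(=O)n(C2CCCC2)c2nc(N/N=C/c3ccc(O)c(F)c3)ncc21` — in this assay compound 2 gives 85200 nM.
Compound 3, `COc1ccc(/C=N/Nc2ncc3c(n2)n(C2CCCC2)c(=O)c(=O)n3C)c(OC)c1` — in this assay compound 3 gives > 100000 nM, again a limit of the assay.

Compound 3 therefore stands at the edge of what this assay can report: its value is only a limit, not a number. Two of the three compounds sit there, as the limit of > 100000 nM in this assay, at which 2 of the 3 values shown sit, records, so the whole set is weak in this assay, and only compound 2 returns a real number.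

Compound 4, `Cn1c(=O)c(=O)n(C2CCCC2)c2nc(N/N=C/c3cccc(O)c3)ncc21`, has not yet been measured. It differs from compound 3 in one place: 3-hydroxyphenyl in place of 2,4-dimethoxyphenyl on a carbon with a double bond to nitrogen. The steps that come closest to this change are a step that the two limits leave unreadable from compound 1 to compound 3 and an at least 1.1-fold higher number from compound 2 to compound 3 (0.06 log units; that floor lies within the scatter). Neither gives a readable size, because one end of each sits at the limit. Compound 4 carries a hydroxyphenyl group, as compound 1 and compound 2 do, though with the hydroxyl placed differently, and both of those gave values at or just inside the limit.

So the expected step is a step that the limit leaves unreadable from compound 3 to compound 4, essentially none beyond the scatter. Compound 4 is estimated at 120000 nM, with a range from 60000 nM to 300000 nM, and most likely the assay will again report only a limit.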

Compound 4, half-maximal inhibitory concentration: 36300 nM
For compound 4 the middle estimate is 3.3-fold (0.52 log units) above the measured one; the measured number lies below the stated range.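

Swapping 4-hydroxyphenyl for 3-hydroxyphenyl on the carbon with a double bond to nitrogen gives an at least 2.7-fold lower number from compound 1 to compound 4 (0.44 log units; beyond the scatter), so in this assay these two hydroxyphenyl groups are not interchangeable. For the compounds shown here, compound 2 was the only earlier compound with a real number, and 3-hydroxyphenyl in place of 3-fluoro-4-hydroxyphenyl gives a 2.3-fold lower number from compound 2 to compound 4 (0.37 log units; beyond the scatter), the first step here with both ends measured, which makes compound 4 the strongest of the four, though its value is still a high number. Replacing 2,4-dimethoxyphenyl with 3-hydroxyphenyl gives an at least 2.7-fold lower number from compound 3 to compound 4 (0.44 log units; beyond the scatter), and this step and the one from compound 1 can only be read as floors, since each starts from a limit rather than a number: the limit of > 100000 nM in this assay, at which 2 of the 4 values shown sit.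

On these data alone, how a 3-methoxyphenyl or a 3-aminophenyl group would compare at this place remains open, as does whether a plain phenyl group would hold the same value, which would show how much the hydroxyl itself contributes. A 3-fluorophenyl or 3-carboxyphenyl group would test the same question further, and with only four compounds in one cell line, nothing yet says whether the step carries over to other cells.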